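Ring saturation at the acyl position of compound 3

The source may report more compounds than this note shows. Statements on the series, on what has been measured and on what is new or still open speak of the compounds shown alone.

Measured so far, in an assay on cells for agonist activity at ecdysone receptor (Bombyx mori), read by a luciferase reporter, with a stated time of 24 h; a higher number here means that more compound is needed for the effect, a lower number that less compound is needed:
- compound 1 `CCc1ccc(C(=O)NN(C(=O)c2ccccc2Cl)C(C)(C)C)cc1` gives 5.75 nM
- compound 2 `CCc1ccc(C(=O)NN(C(=O)c2ccccc2)C(C)(C)C)cc1` gives 4.9 nM
- compound 3 `CCc1ccc(C(=O)NN(C(=O)C2CC=CCC2)C(C)(C)C)cc1` gives 1000 nM

Compound 3 holds the highest number of the three. Both steps leading to it are large and beyond the scatter: a 170-fold higher number from compound 1 to compound 3 (2.24 log units; beyond the scatter) and a 200-fold higher number from compound 2 to compound 3 (2.31 log units; beyond the scatter). The two aromatic acyl compounds lie within the scatter of each other, as a 1.2-fold lower number from compound 1 to compound 2 (0.07 log units; within the scatter) shows, so the chloro substituent on its own does not separate them.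

Compound 4 `CCc1ccc(C(=O)NN(C(=O)C2CCCCC2)C(C)(C)C)cc1` differs from compound 3 only in cyclohexyl in place of cyclohex-3-en-1-yl on a carbonyl carbon. Going by the values given here, no measured pair covers this exact change. The measured steps that reach compound 3 replace an aromatic ring by a non-aromatic one; here the ring stays six-membered and non-aromatic and only loses its one double bond outside aromatic rings. Nothing in this assay yet separates one such non-aromatic ring from another, so the bearing of the measured steps is indirect: they say the aromatic-to-non-aromatic switch costs a lot, not what saturation within the non-aromatic ring does. Compound 4 is therefore expected to stay close to compound 3, with no change at the digits printed from compound 3 to compound 4 (within the scatter) expected to lie within the scatter. The estimate for compound 4 in this assay is 1000 nM, with a range from 300 nM to 3500 nM.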

Compound 4, half-maximal effective concentration: 9330 nM
Compound 4: the middle estimate sits 9.3-fold (0.97 log units) below what was measured; the measured number lies above the stated range.
By their numbers in this assay, from the lowest: compounds 2 and 1 (each within the scatter of the next); then compound 3; then compound 4.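

In this assay, non-aromatic rings on this carbonyl carbon can now be told apart: losing the one double bond outside aromatic rings gives (a 9.3-fold higher number from compound 3 to compound 4 (0.97 log units; beyond the scatter)), so cyclohex-3-en-1-yl and cyclohexyl are not interchangeable here, although both are six-membered non-aromatic rings of carbon only. Replacing the aromatic rings directly with cyclohexyl gives larger steps (a 1900-fold higher number from compound 2 to compound 4 (3.28 log units; beyond the scatter)) and (a 1600-fold higher number from compound 1 to compound 4 (3.21 log units; beyond the scatter)), which places the four compounds in one order: the phenyl and 2-chlorophenyl compounds lowest, then the cyclohex-3-en-1-yl compound, then the cyclohexyl compound, with no listed compound going against it. Going by these compounds alone, nothing at hand explains why the single double bond separates compound 3 and compound 4.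

Open, from the compounds shown here alone, is whether the response follows the double bond itself or its place in the ring, which a cyclohexa-1,4-dien-1-yl or cyclohex-1-en-1-yl group would address. Also open, going by these compounds, is how this carbonyl position responds to rings of another kind, such as cyclopentyl, or piperidinyl with its ring amine.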